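The source may hold more compounds than are shown below. What is called first, only, known or untested is meant among the compounds shown, and "the series" means these compounds.

Measured in an ADME assay on HepG2 cells (Homo sapiens) for cytotoxicity, read by MTT assay, with a stated time of 48 h; on this read-out higher numbers stand for weaker inhibition and lower numbers for stronger inhibition:
- Compound 1 `CC(C)CN1C(=O)/C(=C/c2ccc(N(C)C)cc2)S/C1=N\c1ccccc1`: > 100000 nM, a limit of the assay
- Compound 2 `COc1ccc(/C=C2\S/C(=N\c3ccccc3)N(CC(C)C)C2=O)cc1`: "not determined" (no result reported)
- Compound 3 `COc1cc(/C=C2\S/C(=N\c3ccccc3)N(CC(C)C)C2=O)ccc1O`: 89500 nM

Going by the values given here, compound 3, at 89500 nM, holds the only actual number in this small set. Compound 1 stands at a limit, (the limit of > 100000 nM in this assay, at which 1 of the 3 values shown sits). Compound 2 provides no number for comparison.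

The next compound is compound 4 `CCc1ccc(/C=C2\S/C(=N\c3ccccc3)N(CC(C)C)C2=O)cc1`, and the change is 4-ethylphenyl in place of 4-hydroxy-3-methoxyphenyl on a double-bonded chain carbon bound to a double-bonded ring carbon. It puts 4-ethylphenyl in place of 4-hydroxy-3-methoxyphenyl, on the same double-bonded chain carbon bound to a double-bonded ring carbon.

Among the compounds with values here, only one measured step bears on this place: an at least 1.1-fold lower number from compound 1 to compound 3 (0.04 log units; that floor lies within the scatter). That step involves a different pair of groups, and its floor lies within the scatter, so it gives no direction and only a weak guide to size. No step beyond the scatter is therefore expected in this assay, though this rests on thin evidence. The expected change is a 1.1-fold lower number from compound 3 to compound 4 (0.02 log units; within the scatter).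

Compound 4 is estimated at 85000 nM, with an expected range from 35000 nM to 150000 nM.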

Compound 4, half-maximal inhibitory concentration in the HepG2 assay: 84700 nM
The estimate for compound 4 lay 1.0-fold (0.00 log units) above the measured number, within the range that was stated.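

In the HepG2 assay, 4-ethylphenyl in place of 4-hydroxy-3-methoxyphenyl gives a 1.1-fold lower number from compound 3 to compound 4 (0.02 log units; within the scatter), so at this place the number stays put even though the entering group has 0 hydrogen-bond donors and 0 hydrogen-bond acceptors. In a physicochemical assay for lipophilicity, measured as octanol-water partition (a lower number here means a more polar compound, a higher number a more lipophilic compound), compound 3 gives 4.92 and compound 4 gives 6.34. A large rise in lipophilicity thus left the HepG2 assay unmoved, as the physicochemical assay shows: the measured partition coefficient of compound 3, 4.92, and of compound 4, 6.34, a number 1.42 log units higher (beyond the scatter) In the HepG2 assay compound 1 gives > 100000 nM, a limit of the assay, so the step reads only as an at least 1.1-fold lower number from compound 1 to compound 4 (0.07 log units; that floor lies within the scatter).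

The compounds shown leave open whether a carboxylic acid, a morpholine or a longer alkyl chain on this double-bonded chain carbon would shift the number beyond the scatter. Going by these compounds, the rest of the core is the same throughout, so what a change elsewhere would do also stays open.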